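A large new group on the oxygen of compound 1

The source may report more compounds than this note shows. Statements on the series, on what has been measured and on what is new or still open speak of the compounds shown alone.

Compound 1 `CC1=C2CC(C)(C)/C=C/[C@H](O)/C(C)=C\C3=C[C@H](C)C[C@]3(O2)C1=O` gives 18700 nM in the first test
Compound 2 `CC1=C2CC(C)(C)/C=C/[C@@H](O)/C(C)=C\C3=C[C@H](C)C[C@]3(O2)C1=O` gives 26000 nM in the same test
Compound 3 `CC(=O)O[C@@H]1/C=C/C(C)(C)CC2=C(C)C(=O)[C@]3(C[C@@H](C)C=C3/C=C\1C)O2` gives 26000 nM in the same test

All three numbers come from an ADME assay on HepG2 cells (Homo sapiens) for cytotoxicity, read by CellTiter-Glo, with a stated time of 72 h (a lower number here means that less compound is needed, a higher number that more compound is needed for the effect), and the value of compound 1 lies within the usual scatter of both others. Compound 4 `CC1=C2CC(C)(C)/C=C/[C@H](OC(=S)n3ccnc3)/C(C)=C\C3=C[C@H](C)C[C@]3(O2)C1=O` has not been measured yet. It keeps the core of compound 1 and differs from it in one place: a group of 7 heavy atoms (4 carbon, 2 nitrogen, 1 sulfur; one five-membered aromatic ring with 2 hetero atoms) in place of a hydrogen atom, on an oxygen on a saturated carbon and nothing else.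

For the measured compounds named here, two measured steps bear on this change. The closest is no change at the digits printed from compound 2 to compound 3 (within the scatter) where acetyl took the place of hydrogen on an oxygen on a saturated carbon. That step starts from compound 2 rather than compound 1, but the gap between those two is small: a 1.4-fold higher number from compound 1 to compound 2 (0.14 log units; within the scatter) and it comes with the fact that compounds 1 and 2 differ only in the configuration as drawn as the only structural difference. Neither step moves the number beyond the scatter, so no step beyond the scatter is expected here. Going by the values given here, no measured compound carries the entering group, however, and it is larger than acetyl, so the range must stay wide.

The estimated change for compound 4 is a 1.2-fold lower number from compound 1 to compound 4 (0.10 log units; within the scatter) in this assay as a working expectation. Compound 4 is expected to give about 15000 nM in this test. The estimated range for compound 4 runs from 5000 nM to 32000 nM and the measurement will show where it falls.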

Compound 4, half-maximal effective concentration: 26000 nM
Compound 4: the middle estimate sits 1.7-fold (0.24 log units) below what was measured; low and high end bracket the measured number.
By their numbers in this assay, from the lowest: compounds 1, 2, 3 and 4 (each within the scatter of the next).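

In this assay, placing a group of 7 heavy atoms, with a five-membered aromatic ring with 2 hetero atoms, on this oxygen gives a 1.4-fold higher number from compound 1 to compound 4 (0.14 log units; within the scatter) and so leaves the number where it was within the usual spread of repeats. For the compounds shown here, until now, acetyl was the only group seen on this oxygen, with no change at the digits printed from compound 2 to compound 3 (within the scatter) as its step, so the new result extends that flat picture to a much bigger and very different group, and compounds 3 and 4 together show that a free hydrogen on this oxygen is not required for a number in this range. The two steps start from different compounds, yet they can be read side by side with some care, since the starting points are so closely related: the fact that compounds 1 and 2 differ only in the configuration as drawn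

Going by these compounds, it remains open whether a group of another kind on this oxygen, such as an amine, a carboxylic acid or a longer chain, would move the number beyond the scatter. On these data alone, it is also open whether the group of compound 4 would behave the same way on the opposite drawn configuration, as in compound 2, and which part of that group, the sulfur or the ring, matters, if either does.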